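Five-membered heteroaryl swap on a diarylamine nitrile series

A few compounds are considered here, and "the series" means these few. Any claim that something is new, unique, unknown or untested is made for them only; others in the source may bear on it.

Compound 2 `CCN(c1ccc(C#N)c(Cl)c1)c1cc(-c2ccco2)ccc1C` reaches only a limit in a functional assay on CWR22R cells (Homo sapiens) for antiproliferative activity, read by CCK-8 assay, with a stated time of 6 days (on this read-out lower numbers stand for stronger inhibition and higher numbers for weaker inhibition), giving > 30000 nM, so no single number stands for it. Compound 3 `CCN(c1cccc(-n2ccnc2)c1)c1ccc(C#N)c(C(F)(F)F)c1` gives 19000 nM in this assay, and compound 1 `N#Cc1ccc(N2CCc3cc(-c4cncnc4)ccc32)cc1C(F)(F)F` has "not determined" (no result reported) in this assay. The limit of compound 2 is the one at the limit of > 30000 nM in this assay, at which 1 of the 3 values shown sits. Compound 4 `CCN(c1ccc(C#N)c(Cl)c1)c1cc(-c2cn[nH]c2)ccc1C` differs from compound 2 by 1H-pyrazol-4-yl in place of furan-2-yl on an aromatic carbon. Among the measured compounds shown here, no step between measured compounds covers this change, and a limit gives no starting number, so the size of the move from compound 2 cannot be read from the data; anything from none beyond the scatter to a modest gain is open. Compound 4 is expected to give 20000 nM, between 5000 nM and 60000 nM, which amounts to an expected step of an at least 1.5-fold lower number from compound 2 to compound 4 (0.17 log units; that floor lies within the scatter).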

Compound 4, half-maximal inhibitory concentration: > 30000 nM
Compound 4: no number, only a limit (the forecaster's own chance of this, stated with the estimate: 40%); at least 1.5-fold (0.17 log units) between middle value and limit.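

Compound 2 and compound 4 both stand only at a limit in this assay, so no step between them can be read: the limit of > 30000 nM in this assay, at which 2 of the 4 values shown sit.

Whether 1H-pyrazol-4-yl in place of furan-2-yl shifts the read-out at all stays open in the compounds shown.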